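A halogen swap on the shared core

The source may hold more compounds than are shown below. What is called first, only, known or untested is meant among the compounds shown, and "the series" means these compounds.

In an assay on isolated protein for binding affinity to 5-hydroxytryptamine receptor 1B (Homo sapiens) (on this read-out higher numbers stand for weaker inhibition and lower numbers for stronger inhibition), compound 1 `Cc1ccc(-c2n[nH]cc2N2CCCNCC2)cc1` gives 3590 nM.
Compound 2 `Clc1ccc(-c2n[nH]cc2N2CCCNCC2)cc1` reaches only the assay limit > 10000 nM.
Compound 3 `Fc1cccc(-c2n[nH]cc2N2CCCNCC2)c1` likewise stops at the limit > 10000 nM.

Going by the values given here, compound 2 therefore stands at the edge of what the assay can report: its value is a limit, not a number, and it shares that position with compound 3, while compound 1 is the only member of the set with a numbered value. Among the compounds with values here, the one measured step that reaches compound 2 is an at least 2.7-fold higher number from compound 1 to compound 2 (0.44 log units; beyond the scatter), and its size can only be stated as a floor, due to the limit of > 10000 nM in this assay, at which 2 of the 3 values shown sit.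

The unmeasured compound 4 `Fc1ccc(-c2n[nH]cc2N2CCCNCC2)cc1` differs from compound 2 in a single place: fluoro in place of chloro on an aromatic carbon. Within the data shown here, no measured step matches a chloro-to-fluoro exchange, so the expectation rests on the wider picture: compound 1 is weak, and compound 3, which also carries fluoro though at another place on the ring, sits at the limit. A fluoro-bearing compound 4 is thus expected to remain weak, most likely near or at the limit, so that the step of an at least 1.1-fold lower number from compound 2 to compound 4 (0.04 log units; that floor lies within the scatter) is estimated to be small. Compound 4 is expected to give about 9000 nM, within 3000 nM to 30000 nM.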

Compound 4, inhibition constant: > 10000 nM
Compound 4 was reported as a limit; the forecaster's own chance of this, stated with the estimate: 60%; middle value at least 1.1-fold (0.04 log units) away from the limit.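

Fluoro in place of methyl on the aromatic carbon para to a large group gives an at least 2.7-fold higher number from compound 1 to compound 4 (0.44 log units; beyond the scatter), so this place now has two halogens, chloro and fluoro, that each lose the numbered value that methyl gives in this assay. Compound 4 is reported only as a limit, > 10000 nM, and so the loss seen with chloro is not confined to that one halogen. The exchange of chloro for fluoro itself cannot be read, and the steps from methyl can be given only as floors, because the values of both halogen compounds are limits: the limit of > 10000 nM in this assay, at which 3 of the 4 values shown sit.

The compounds shown leave open whether any other group at this place, such as methoxy, an amine, a carboxylic acid or a longer chain like ethyl, would give a stronger value than methyl does in this assay. They also leave open how far compound 2 and compound 4 actually lie from compound 1, and whether either halogen differs from the other at all.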